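The compounds below may be only part of what the source reports. "The series", "measured", "known", "first", "only" and "open" are said of these compounds alone.

Measured compounds in a functional assay on MCF7 cells (Homo sapiens) for antiproliferative activity; a lower number here means a stronger inhibitor, a higher number a weaker inhibitor:
Compound 1, `CCN(C)CCCOc1ccc2cc(NC(=O)c3ccc(O)c(CC=C(C)C)c3)c(=O)oc2c1C`, gives 2190 nM.
Compound 2, `CC(C)=CCc1cc(C(=O)Nc2cc3ccc(OCCCNC(C)(C)C)c(C)c3oc2=O)ccc1O`, gives 950 nM.
Compound 3, `CC(C)=CCc1cc(C(=O)Nc2cc3ccc(OCCCNCCO)c(C)c3oc2=O)ccc1O`, gives 1560 nM.

Among these three numbers compound 3 stands second highest. Its nearest neighbour is compound 1, whose value differs from it only within the usual scatter, and compound 2 lies further off, yet the difference a 1.6-fold higher number from compound 2 to compound 3 (0.22 log units; within the scatter) is also within the scatter, so compound 3 cannot be ordered against either of them.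

Compound 4, `CC(C)=CCc1cc(C(=O)Nc2cc3ccc(OCCCN[C@@H]4C[C@H]5CC[C@@H]4C5)c(C)c3oc2=O)ccc1O`, arises from compound 3 by a single change on the amine nitrogen: a group of 7 heavy atoms (7 carbon; 2 five-membered non-aromatic rings of carbon only) in place of a group of 3 heavy atoms (2 carbon, 1 oxygen; no ring), on an amine nitrogen.

Within the data shown here, two measured steps touch the same amine nitrogen. In the first, a 2.3-fold lower number from compound 1 to compound 2 (0.36 log units; beyond the scatter), with (tert-butyl)amino in place of ethyl(methyl)amino. In the second, a 1.6-fold higher number from compound 2 to compound 3 (0.22 log units; within the scatter), with 2-hydroxyethyl in place of tert-butyl. Of the two groups on that nitrogen, the one without oxygen and without a donor, tert-butyl, went with the lowest number in this assay, and compound 4 carries the larger all-carbon group of the pair. The expectation for compound 4 is therefore a modest lowering from compound 3, a 2.0-fold lower number from compound 3 to compound 4 (0.29 log units; within the scatter), of about the size seen in the step from compound 1 to compound 2, though the step from compound 2 to compound 3 was itself within the scatter, so the lowering may not exceed the scatter. The estimate for compound 4 is 800 nM, with a range from 350 nM to 1800 nM.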

Compound 4, half-maximal inhibitory concentration: 1030 nM
Beside the measured number, compound 4's estimate is 1.3-fold (0.11 log units) below it, within the range that was stated.
By their numbers in this assay, from the lowest: compounds 2, 4, 3 and 1 (each within the scatter of the next, the first and the last beyond it).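

In this assay, the larger all-carbon group of two five-membered rings on the amine nitrogen gives a 1.1-fold higher number from compound 2 to compound 4 (0.04 log units; within the scatter) in place of tert-butyl, so going from a group of four carbons to one of seven, with rings added, brings no change that can be told from the scatter. Against the hydroxyethyl group the result is also unresolved, with a 1.5-fold lower number from compound 3 to compound 4 (0.18 log units; within the scatter), and so the comparison of an oxygen-bearing group with an all-carbon one at this nitrogen remains undecided. What compound 4 adds is a second compound carrying an all-carbon group on this nitrogen that stands clear of the ethyl(methyl)amino compound, with a 2.1-fold lower number from compound 1 to compound 4 (0.33 log units; beyond the scatter), while compound 3 does not stand clear of it; no measurement here offers an explanation for this, and no supporting data bear on it.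

The compounds shown leave open whether the three defined stereocentres of the new group matter, as only one arrangement of them appears here. They also leave open what a primary amine, a carboxylic acid or a phenyl group on this nitrogen would give, and what a longer chain would give.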